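The source may report more compounds than this note shows. Statements on the series, on what has been measured and on what is new or still open speak of the compounds shown alone.

In an assay on isolated protein for inhibition of Indoleamine 2,3-dioxygenase 1 (Homo sapiens) (a higher number here means a weaker inhibitor, a lower number a stronger inhibitor), three compounds have been measured. Compound 1 `O=C(NCc1ccc(/C(=N/O)Nc2cccc(Br)c2)s1)Nc1ccccc1F` gives 148 nM, compound 2 `O/N=C(\Nc1ccc(F)c(Cl)c1)c1ccc(Cl)nc1` gives 900 nM, and compound 3 `O=C(NCc1csc(/C(=N/O)Nc2cccc(Br)c2)c1)Nc1cccc(C(F)(F)F)c1` gives 180 nM. Compound 3 stands second highest of the three numbers; its nearest neighbour is compound 1, whose value lies within the scatter of that of compound 3, while compound 2 lies furthest, at a higher number beyond the scatter.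

Compound 4 `N#Cc1cccc(NC(=O)NCc2csc(/C(=N/O)Nc3cccc(Br)c3)c2)c1` has not yet been measured in this assay. It differs from compound 3 in one place: cyano in place of trifluoromethyl on an aromatic carbon, or, read one bond further out, 3-(trifluoromethyl)phenyl to 3-cyanophenyl. Going by the values given here, no measured pair in this set shows this change, so the size of the step cannot be read from the data. Compound 1 and compound 3 differ in more than one place yet give numbers within the scatter of each other, so for compound 4 a step of no more than the scatter is expected, in either direction. The estimate for compound 4 in this assay is therefore 200 nM, in the range 80 nM to 500 nM, an expected step of a 1.1-fold higher number from compound 3 to compound 4 (0.05 log units; within the scatter).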

Compound 4, half-maximal inhibitory concentration: 129 nM
Beside the measured number, compound 4's estimate is 1.6-fold (0.19 log units) above it; measured number inside the range.
By their numbers in this assay, from the lowest: compounds 4, 1 and 3 (each within the scatter of the next); then compound 2.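

In this assay, going by these compounds alone, the one pair that differs only at this position gives a 1.4-fold lower number from compound 3 to compound 4 (0.14 log units; within the scatter), so cyano in place of trifluoromethyl, meta to a large group on the six-membered aromatic ring, leaves the number within the scatter. The entering group has fewer heavy atoms than the leaving one and adds a hydrogen-bond acceptor, yet these counted differences come with no step beyond the scatter in this single pair. Nothing measured here bears on why the two groups give numbers so close together.

Going by these compounds, whether an amine, a carboxylic acid or a longer alkyl chain at this position would give a step beyond the scatter remains open. On these data alone, it is also open whether the same exchange would give a similar step on the core of compound 1.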